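The source may hold more compounds than are shown below. What is called first, only, known or untested is meant among the compounds shown, and "the series" means these compounds.

Measured so far in a functional assay on CCRF-CEM cells (Homo sapiens) for antiproliferative activity, read by cell counting, with a stated time of 72 h; on this read-out lower numbers stand for stronger inhibition and higher numbers for weaker inhibition (a lower number means stronger inhibition):

- compound 1 `C#C[C@@]1(O)[C@@H](CO)O[C@@H](n2cc(F)c3c(N)ncnc32)[C@@H]1O` gives 160 nM
- compound 2 `C#C[C@@]1(O)[C@@H](CO)O[C@@H](n2cc(Br)c3c(N)ncnc32)[C@@H]1O` gives 30 nM
- compound 3 `C#C[C@@]1(O)[C@@H](CO)O[C@@H](n2cc(Cl)c3c(Cl)ccnc32)[C@@H]1O` gives 1300 nM

Compound 3 has the highest number of the three, which makes it the weakest inhibitor in this small set, and both gaps to the other two compounds are beyond the usual scatter. Compound 4 `C#C[C@@]1(O)[C@@H](CO)O[C@@H](n2cc(Br)c3c(Cl)ccnc32)[C@@H]1O` keeps everything in compound 3 except one atom: bromo in place of chloro on an aromatic carbon. In short, bromo takes the place of chloro on an aromatic carbon of the five-membered ring.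

Among the compounds with values here, one measured step bears on this swap. It is a 5.3-fold lower number from compound 1 to compound 2 (0.73 log units; beyond the scatter), which also puts bromo on that carbon, and it is a modest change beyond the scatter. Two cautions apply. That step replaces fluoro rather than chloro, and compounds 1 and 2 differ from compound 3 elsewhere on the core. Within the data shown here, no chloro-to-bromo pair has been measured.

A lower number is therefore expected, but a step smaller than the one seen for fluoro. The expected change is a 2.4-fold lower number from compound 3 to compound 4 (0.37 log units; beyond the scatter) in this assay. The estimate for compound 4 is 550 nM, with an expected range from 180 nM to 1400 nM.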

Compound 4, half-maximal inhibitory concentration: 560 nM
Compound 4: middle estimate off by 1.0-fold (0.01 log units), on the low side; measured number inside the range.
By their numbers in this assay, from the lowest: compound 2; then compound 1; then compound 4; then compound 3.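

In this assay, within the data shown here, this is the first direct chloro-to-bromo pair at this carbon of the five-membered ring, and the swap gives a 2.3-fold lower number from compound 3 to compound 4 (0.37 log units; beyond the scatter). Bromo also lowered the number on the core of compound 1, with a 5.3-fold lower number from compound 1 to compound 2 (0.73 log units; beyond the scatter), so the same direction now appears on two different cores and with two different halogens being replaced, although these four compounds are too few to call this a general rule. No measurement shown here explains why a single halogen swap at this carbon changes the antiproliferative read-out.

On these data alone, it remains open whether the numbers would keep falling with iodo at this carbon, or whether a non-halogen group such as methyl or a nitrile would do as well as bromo. A chloro group on the core of compound 1 would also be informative, as it would place fluoro, chloro and bromo side by side on one core and show how much of the larger step seen from fluoro belongs to the halogen itself.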